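A few compounds are considered here, and "the series" means these few. Any claim that something is new, unique, unknown or untested is made for them only; others in the source may bear on it.

Compound 1 `C=C1C(=O)O[C@H]2[C@H]1CC/C(COC(=O)Cn1cc(F)c(=O)[nH]c1=O)=C\CC[C@@]1(C)O[C@@H]21` was tested in a functional assay on Bel7402/5-FU cells (Homo sapiens) for antiproliferative activity, read by MTT assay, with a stated time of 72 h; a lower number here means a stronger inhibitor, a higher number a weaker inhibitor. In this assay compound 1 gives > 20000 nM, which is a limit of the assay and not a number. Its place on the scale is known only as that limit. Among the compounds with values here, compound 2 `C=C1C(=O)O[C@H]2[C@H]1CC/C(Cn1cc(Cn3cc(F)c(=O)n(Cc4ccccc4)c3=O)nn1)=C\CC[C@@]1(C)O[C@@H]21`, the only other compound measured, gives 8840 nM in this assay. Compound 2 also carries a benzyl group on an aromatic nitrogen, but it differs from compound 1 in its link to the shared core as well, so its value cannot be assigned to that group alone.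

Compound 3 `C=C1C(=O)O[C@H]2[C@H]1CC/C(COC(=O)Cn1cc(F)c(=O)n(Cc3ccc(Br)cc3)c1=O)=C\CC[C@@]1(C)O[C@@H]21` keeps the ester link of compound 1 and changes in one place: 4-bromobenzyl in place of hydrogen on an aromatic nitrogen. Thus 4-bromobenzyl stands in place of hydrogen on an aromatic nitrogen. A modest move toward stronger inhibition is expected in this assay, with the reasoning resting on compound 2 at 8840 nM. Even so, compound 3 may yet stay at the limit. The expected step, an at least 2.2-fold lower number from compound 1 to compound 3 (0.34 log units; beyond the scatter), is only an estimate. For compound 3 the estimated value is 9000 nM, with an expected range from 3000 nM to 20000 nM.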

Compound 3, half-maximal inhibitory concentration: 3240 nM
Estimate against measurement, compound 3: 2.8-fold (0.44 log units) above; the measured number falls inside the stated range.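

Within the data shown here, with the ester link kept, 4-bromobenzyl in place of hydrogen on the aromatic nitrogen gives in this assay an at least 6.1-fold lower number from compound 1 to compound 3 (0.79 log units; beyond the scatter) and this is the first reading of a change at this position that rests on a single difference, which the earlier pair could not offer, as compound 2 also differs in its link to the shared core. The position therefore takes a group of this size, with one six-membered aromatic ring of carbon, and the number falls by a step beyond the usual scatter. Compound 1 gives > 20000 nM and that is a limit of the assay and not a number, so the step has a floor but no known full size: the limit of > 20000 nM in this assay, at which 1 of the 3 values shown sits.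

The compounds shown leave open whether the gain belongs to the benzyl group as such or to its bromine, a question that a plain benzyl, a 4-chlorobenzyl or a 4-methoxybenzyl on the same nitrogen would address. They also leave open how a small methyl, a longer alkyl chain or a chain ending in an amine would read at this position with the ester link in place.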